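The compounds below may be only part of what the source reports. "The series", "measured", "known", "first", "only" and "open" are said of these compounds alone.

Of the compounds shown here, three have been measured in a functional assay on DU-145 cells (Homo sapiens) for cytotoxicity, read by MTT assay, with a stated time of 48 h; a higher number here means a weaker inhibitor, a lower number a stronger inhibitor: compound 1 `COc1ccc(-c2cc(C(=O)Nc3nc4ccc(Cl)cc4s3)nc3cc(-c4ccccc4)nn23)cc1` gives 5880 nM, compound 2 `COc1ccc(-c2cc(C(=O)Nc3nc4ccc(F)cc4s3)nc3cc(-c4ccccc4)nn23)cc1` gives 31400 nM, and compound 3 `COc1ccc2nc(NC(=O)c3cc(-c4ccc(F)cc4)n4nc(-c5ccccc5)cc4n3)sc2c1` gives 15400 nM.

Compound 3 stands second highest of the three numbers, its value lying between those of compound 1 and compound 2. Compound 4 `COc1ccc(-c2cc(C(=O)Nc3nc4ccc(OC)cc4s3)nc3cc(-c4ccccc4)nn23)cc1` differs from compound 3 by methoxy in place of fluoro on an aromatic carbon. For the measured compounds named here, the single measured step, a 5.3-fold higher number from compound 1 to compound 2 (0.73 log units; beyond the scatter), concerns a different ring and a different pair of groups, so it bears on this change only loosely, and no measured pair exchanges fluoro for methoxy anywhere. The expected step from compound 3 to compound 4 in this assay is therefore a 1.3-fold lower number from compound 3 to compound 4 (0.11 log units; within the scatter), not beyond the scatter. Compound 4 is estimated to give 12000 nM, with a range from 4000 nM to 35000 nM.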

Compound 4, half-maximal inhibitory concentration: 7580 nM
The estimate for compound 4 lay 1.6-fold (0.20 log units) above the measured number; the range from low to high includes it.
By their numbers in this assay, from the lowest: compounds 1 and 4 (each within the scatter of the next); then compound 3; then compound 2.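

In this assay methoxy in place of fluoro lowers the number at both places where the exchange can now be read, with a 2.0-fold lower number from compound 3 to compound 4 (0.31 log units; beyond the scatter) as 4-fluorophenyl becomes 4-methoxyphenyl and a 4.1-fold lower number from compound 2 to compound 4 (0.62 log units; beyond the scatter) on the ring that carries chloro in compound 1. On that ring chloro and methoxy cannot be told apart, with a 1.3-fold higher number from compound 1 to compound 4 (0.11 log units; within the scatter) there, so fluoro alone stands apart among the three groups. No measured evidence accounts for these steps.

As far as these compounds go, what an amine or a hydroxyl would do at either place remains open.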